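A second fluoro on the nitrophenyl ring

The source may hold more compounds than are shown below. What is called first, only, known or untested is meant among the compounds shown, and "the series" means these compounds.

The measured compounds are:
compound 1, `Nc1nc(N)c(CCCN(Cc2ccc(NC(CCC(=O)O)C(=O)O)cc2)c2cc(F)c(F)cc2[N+](=O)[O-])c(O)n1`: > 100000 nM
compound 2, `Nc1nc(N)c(CCCNc2cc(F)c(F)cc2[N+](=O)[O-])c(O)n1`: 97000 nM
compound 3, `COC(=O)c1ccc(CN(CCCc2c(N)nc(N)nc2O)c2cc(F)ccc2[N+](=O)[O-])cc1`: 55000 nM

In a functional assay on CCRF-CEM cells (Homo sapiens) for cytotoxicity, in the absence of a further agent (a lower number here means a stronger inhibitor, a higher number a weaker inhibitor), compound 3 gives 55000 nM, the lowest of the two numbers shown. Compound 2 gives 97000 nM in this assay, and the gap between it and compound 3 lies within the scatter, so no order between the two can be read. For compound 1 the result in this assay is only a limit of the assay, not a number: the limit of > 100000 nM in this assay, at which 1 of the 3 values shown sits.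

Compound 4, `COC(=O)c1ccc(CN(CCCc2c(N)nc(N)nc2O)c2cc(F)c(F)cc2[N+](=O)[O-])cc1`, has not yet been measured. Its change from compound 3 is fluoro in place of hydrogen on an aromatic carbon. Within the data shown here, no pair of measured compounds differs in a single place, so no measured step exists to guide the size of this change. With the two numbers shown within the scatter of each other, the account expects no step beyond the scatter in this assay for this change. Compound 4 is therefore estimated at 60000 nM in this assay, between 25000 nM and 150000 nM. The expected step of a 1.1-fold higher number from compound 3 to compound 4 (0.04 log units; within the scatter) lies within the scatter.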

Compound 4, half-maximal inhibitory concentration: 66000 nM
The estimate for compound 4 lay 1.1-fold (0.04 log units) below the measured number; the range from low to high includes it.
By their numbers in this assay, from the lowest: compounds 3, 4 and 2 (each within the scatter of the next). At a limit, above all of these: compound 1.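

The step from 5-fluoro-2-nitrophenyl to 4,5-difluoro-2-nitrophenyl, fluoro in place of hydrogen on an aromatic carbon, ortho to a fluoro group and meta to a nitro group, gives in this assay a 1.2-fold higher number from compound 3 to compound 4 (0.08 log units; within the scatter). The 4-(methoxycarbonyl)benzyl group on the nitrogen gives a 1.5-fold lower number from compound 2 to compound 4 (0.17 log units; within the scatter), which likewise cannot be told apart from the scatter. Methoxycarbonyl in place of (1,3-dicarboxypropyl)amino on an aromatic carbon gives an at least 1.5-fold lower number from compound 1 to compound 4 (0.18 log units; that floor lies within the scatter), and this step can be read only as a floor. Compound 1 stands at a limit and not at a number: the limit of > 100000 nM in this assay, at which 1 of the 4 values shown sits.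

The compounds shown leave open whether chloro, methoxy or an amine at this position would give a step beyond the scatter. They also leave open what a carboxylic acid in place of the methoxycarbonyl would give with the 4,5-difluoro-2-nitrophenyl kept.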